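The source may report more compounds than this note shows. Statements on the series, on what has been measured and on what is new or still open speak of the compounds shown alone.

Working notes on the series. Compound 1 `CCn1c(CNc2ccccc2)nnc1SCC(=O)Nc1ccc(C(=O)OC)cc1` has no figure of its own: in an assay on isolated protein for inhibition of long-chain fatty acid transport protein 1 (Mus musculus) (a higher number here means a weaker inhibitor, a lower number a stronger inhibitor), compound 1 stands at "not determined" (no result reported), and compound 2 `CCn1c(CNc2ccccc2)nnc1SCC(=O)Nc1ccc(C(C)=O)cc1` likewise stands at "not determined" (no result reported). Within the data shown here, the only number in the set belongs to compound 3 `CCn1c(CNc2ccccc2)nnc1SCc1nc2cc(Cl)ccc2o1`, which in this assay gives 2300 nM. Compound 4 `CCn1c(CNc2ccccc2)nnc1SCC(=O)Nc1ccc(C(=O)NC)cc1` differs from compound 1 by methylamino in place of methoxy on a carbonyl carbon. Among the measured compounds shown here, no measured pair spans this change, so the size of the step in this assay is not known; with nothing to anchor it, the expectation is a step of no more than the usual scatter in either direction, set against the level of compound 3. Compound 4 is therefore estimated at 2500 nM, with a range of 500 nM to 12000 nM.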

Compound 4, half-maximal inhibitory concentration: > 10000 nM
Compound 4 was reported as a limit; the forecaster's own chance of this, stated with the estimate: 30%; at least 4.0-fold (0.60 log units) between middle value and limit.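

No step can be read between compound 1 and compound 4: compound 1 has no number, and compound 4 carries only a limit (> 10000 nM). The compounds shown leave open what methylamino in place of methoxy does in this assay on the shared core.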